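The compounds below may be only part of what the source reports. "The series", "measured", "known", "first", "only" and "open" are said of these compounds alone.

Compound 1, `CC(C)c1ccnc(C(=O)Nc2nn[nH]n2)c1`: 34%
Compound 2, `O=C(Nc1nn[nH]n1)c1cccnc1`: 4%
Compound 3, `CNc1ccc(-c2cc(C)cc(C(=O)Nc3nn[nH]n3)n2)cc1`: 89%

All three were tested in a functional assay on the whole organism for inhibition, with Rattus norvegicus as the target, at a dose of 3 mg/kg by the oral route; a higher number here means a stronger effect of the compound at the dose given, a lower number a weaker effect. Among these three numbers compound 1 stands second highest with 34%: compound 2 lies lower by a margin beyond the usual scatter, and compound 3 lies higher by a still larger margin, also beyond the scatter.

Compound 4, `O=C(Nc1nn[nH]n1)c1ccccn1`, has not yet been measured. It differs from compound 1 in one place: hydrogen in place of isopropyl on an aromatic carbon. The isopropyl leaves and a hydrogen atom enters, on an aromatic carbon of a six-membered aromatic ring with 1 nitrogen, opposite the ring nitrogen.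

Within the data shown here, no two measured compounds differ by just this change, so no measured step can be read off. The expectation leans on compound 2, which carries no isopropyl and gives 4%. A drop beyond the scatter is therefore expected in this assay. For compound 4 the estimate is 12%, with a range from 0% to 35%. The expected step is a number 22 percentage points lower from compound 1 to compound 4 (beyond the scatter).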

Compound 4, a percentage reported as inhibition, in the whole organism at one dose (the size of the read-out at that dose, not a potency): 29%
Compound 4: the middle estimate sits 17 percentage points below what was measured; low and high end bracket the measured number.
By their numbers in this assay, from the lowest: compound 2; then compounds 4 and 1 (each within the scatter of the next); then compound 3.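

In this assay the isopropyl opposite the ring nitrogen can be replaced by hydrogen with only a small step (a number 5 percentage points lower from compound 1 to compound 4 (within the scatter)), which lies within the scatter. At this dose, then, the isopropyl makes no measurable difference to the read-out, so the effect of compound 1 does not depend on this group. The read-out is taken at a single dose, so this is a statement about the size of the effect and not about potency, and nothing shown explains the result.

Still open, from the compounds shown here alone, is whether a different group at this same place would move the number beyond the scatter, such as an amine, a carboxylic acid, a methoxy group or a phenyl ring. A longer chain in place of the isopropyl is equally untested by the compounds shown here.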